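Swapping one halogenated ring for another in an amide series

The source may report more compounds than this note shows. Statements on the series, on what has been measured and on what is new or still open speak of the compounds shown alone.

Measured compounds:
- compound 1 `O=C(Nc1cccc(F)c1)c1cncc(N2CC3CC(C2)N3)c1`: 0.044 nM
- compound 2 `COc1cc(NC(=O)c2cncc(N3CC4CC(C3)N4)c2)cc(OC)c1`: 0.985 nM
- compound 3 `O=C(c1cncc(N2CC3CC(C2)N3)c1)N1CCc2ccccc2C1`: 0.031 nM

All three share the same core and were tested in an assay on membranes from Cerebral cortex for displacement of a labelled ligand from Neuronal acetylcholine receptor; alpha4/beta2 (Rattus norvegicus); a lower number here means a stronger inhibitor, a higher number a weaker inhibitor. Compound 1 gives 0.044 nM, and compound 3 gives 0.031 nM; these two values lie within the scatter of each other, so no order between them can be read. Compound 2 gives 0.985 nM, a higher number than compound 1, and that gap lies beyond the scatter.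

Compound 4 `O=C(Nc1ccc(Cl)cc1)c1cncc(N2CC3CC(C2)N3)c1` has not been measured. It differs from compound 1 in one place: 4-chlorophenyl in place of 3-fluorophenyl on an amide-type nitrogen. Among the measured compounds shown here, no pair among the measured compounds shows exactly this kind of exchange, so the size of the step has to be guessed from the spread of the measured values. A modest move toward a higher number seems plausible, but a step within the scatter cannot be excluded. Compound 4 is therefore expected to give about 0.1 nM, in the range 0.03 nM to 0.4 nM, which corresponds to an estimated step of a 2.3-fold higher number from compound 1 to compound 4 (0.36 log units; beyond the scatter).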

Compound 4, inhibition constant: 0.404 nM
Compound 4: the middle estimate sits 4.0-fold (0.61 log units) below what was measured, outside the stated range (above it).
By their numbers in this assay, from the lowest: compounds 3 and 1 (each within the scatter of the next); then compound 4; then compound 2.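

In this assay the exchange of 3-fluorophenyl for 4-chlorophenyl on an amide-type nitrogen brings a 9.2-fold higher number from compound 1 to compound 4 (0.96 log units; beyond the scatter) and so shows that this position responds to a change in what the ring carries. The step is large even though the count of heavy atoms stays the same and a single aromatic ring of carbon remains in place. Nothing available here accounts for the size or direction of this step.

The halogen and its place on the ring change together in this exchange, so the compounds shown leave open how much of the step belongs to each. They also leave open how this position would respond to a plain phenyl ring, or to a ring carrying an amine or a carboxylic acid.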